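Same sulfonyl swap, second pair of compounds

The source may hold more compounds than are shown below. What is called first, only, known or untested is meant among the compounds shown, and "the series" means these compounds.

Compound 1 `COc1ccc(Cc2nnc(NC(=O)/C(C#N)=C/c3ccccc3OS(=O)(=O)c3ccccc3[N+](=O)[O-])s2)cc1` and compound 2 `COc1ccc(Cc2nnc(NC(=O)/C(C#N)=C/c3ccccc3OS(=O)(=O)c3ccc(Cl)cc3)s2)cc1` share a core and differ by 4-chlorophenyl in place of 2-nitrophenyl on a sulfonyl sulfur. In a functional assay on HL-60 cells (Homo sapiens) for inhibition, read by CCK-8 assay, with a stated time of 48 h, tested at 20 uM (a higher number here means more inhibition of growth at the concentration tested, a lower number less inhibition of growth), compound 1 gives 25%, and compound 2 gives 20%. The step is a number 5 percentage points lower from compound 1 to compound 2 (within the scatter). Compound 3 `Cc1ccc(Cc2nnc(NC(=O)/C(C#N)=C/c3ccccc3OS(=O)(=O)c3ccccc3[N+](=O)[O-])s2)cc1` differs from compound 1 by methyl in place of methoxy on an aromatic carbon. In this assay compound 3 gives 33%, a step of a number 8 percentage points higher from compound 1 to compound 3 (within the scatter). Of the three measured numbers compound 3 holds the highest, though its gap to compound 1 lies within the scatter and only its gap to compound 2 lies beyond it.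

Compound 4 `Cc1ccc(Cc2nnc(NC(=O)/C(C#N)=C/c3ccccc3OS(=O)(=O)c3ccc(Cl)cc3)s2)cc1` has not yet been measured. It differs from compound 3 by 4-chlorophenyl in place of 2-nitrophenyl on a sulfonyl sulfur. Among the measured compounds shown here, this is the same change as the one between compound 1 and compound 2, at the same place and with the same surroundings. The step expected from compound 3 to compound 4 is a number 5 percentage points lower from compound 3 to compound 4 (within the scatter), resting on compound 1 and compound 2 because a number 5 percentage points lower from compound 1 to compound 2 (within the scatter). On that basis compound 4 is estimated at 28%, with a range from 15% to 40%.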

Compound 4, percent growth inhibition at one concentration: 38%
Compound 4: middle estimate off by 10 percentage points, on the low side, within the range that was stated.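

In this assay the sulfonyl swap on the methyl core gives a number 5 percentage points higher from compound 3 to compound 4 (within the scatter), and this step does not differ beyond the scatter from the one on the methoxy core: the same change on two cores in this assay, a number 5 percentage points lower (within the scatter) from compound 1 to compound 2 and a number 5 percentage points higher (within the scatter) from compound 3 to compound 4, 10 percentage points apart, within the scatter of two such steps. The change from methoxy to methyl, read on the 4-chlorophenyl sulfonyl compounds, gives a number 18 percentage points higher from compound 2 to compound 4 (beyond the scatter), and it also agrees with its earlier counterpart on the 2-nitrophenyl sulfonyl compounds: the same change on two cores in this assay, a number 8 percentage points higher (within the scatter) from compound 1 to compound 3 and a number 18 percentage points higher (beyond the scatter) from compound 2 to compound 4, 10 percentage points apart, within the scatter of two such steps. Among the compounds shown here, both changes are therefore compatible with carrying from one core to the other, but with only two pairs for each, this does not show that the sulfonyl swap itself shifts growth inhibition or that the methyl step has a fixed size.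

On these data alone, it remains open how these steps would read with a plain phenyl or a morpholine on the sulfonyl sulfur, or with an amine or a carboxylic acid in place of the methyl on the aromatic carbon. Also open, as far as these compounds go, is whether the same steps would hold at other concentrations.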